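Indole-oxadiazole series: trifluoromethyl replacing the aryl group

This account rests on a few compounds, and the source may have more. Where it says the series, first, only, none or still open, it means among the compounds named here.

Compound 1 `c1ccc(-c2nnc(-c3c[nH]c4ccccc34)o2)cc1` carries a phenyl on the shared core. In a functional assay on MIA PaCa-2 cells (Homo sapiens) for cytotoxicity, read by MTT assay (on this read-out lower numbers stand for stronger inhibition and higher numbers for weaker inhibition), compound 1 returns only a limit of the assay, > 1000000 nM. Compound 2 `COc1ccc(-c2nnc(-c3c[nH]c4ccccc34)o2)cc1OC` likewise gives a limit in this assay, > 1000000 nM. Compound 3 `COc1ccc(-c2nnc(-c3c[nH]c4ccccc34)o2)c(OC)c1OC` gives a limit as well in this assay, > 1000000 nM. All three values sit at the same point, (the limit of > 1000000 nM in this assay, at which 3 of the 3 values shown sit), so compound 1 cannot be placed relative to the others. Among the measured compounds shown here, the single step within the measured set, a step that the two limits leave unreadable from compound 2 to compound 3, is left unreadable by the two limits.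

Compound 4 `FC(F)(F)c1nnc(-c2c[nH]c3ccccc23)o1` differs from compound 1 by trifluoromethyl in place of phenyl on an aromatic carbon. For the measured compounds named here, no measured step touches this change; the only step in hand, a step that the two limits leave unreadable from compound 2 to compound 3, concerns a methoxy on the phenyl and gives no size. With every measured compound at the limit, no step beyond the scatter can be expected in this assay in either direction. The estimate for compound 4 is 1000000 nM, within 100000 nM to 1000000 nM, which would mean an expected step of a number no higher from compound 1 to compound 4 (the limit leaves the size open), most likely again reported only as a limit.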

Compound 4, half-maximal inhibitory concentration: > 1000000 nM
Compound 4: no number, only a limit; the forecaster's own chance of this, stated with the estimate: 85%; the middle value sits exactly at the limit.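

In this assay compound 4 gives only a limit, > 1000000 nM. Compound 1 is a limit too, so no step can be read from compound 1 to compound 4: the limit of > 1000000 nM in this assay, at which 4 of the 4 values shown sit.

The compounds shown leave open how phenyl and trifluoromethyl compare on the shared core.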